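The source may report more compounds than this note shows. Statements on the series, on what has been measured and on what is new or still open speak of the compounds shown alone.

Three compounds share a core in which a bicyclic ring system carries an unsaturated amide side chain. Compound 1 `CC(C)NC(=O)/C=C1\CCc2ccc(F)cc21` and compound 2 `CCN(C)C(=O)/C=C1\CCc2ccc(F)cc21` each bear a single fluoro group on the aromatic ring and differ only in the amine part of the amide. In a functional assay on the whole organism with Mus musculus as the target, at a dose of 100 mg/kg by the intraperitoneal route (a higher number here means more inhibition at the dose given (going by the name of the read-out), a lower number less inhibition), compound 1 gives 100%, and compound 2 gives 100%; the change from one amide to the other, no change at the digits printed from compound 1 to compound 2 (within the scatter), leaves the read-out unmoved within the scatter. Compound 3 `O=C(/C=C1\CCc2cc(F)c(F)cc21)NC1CC1` carries a cyclopropylamino amide and two fluoro groups on the aromatic ring; in this assay compound 3 gives 50%, the lowest of the three numbers and well beyond the scatter below both compound 1 and compound 2.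

Compound 4 `O=C(/C=C1\CCc2ccc(F)cc21)NC1CC1` is obtained from compound 3 by one change: hydrogen in place of fluoro on an aromatic carbon. The fluoro that leaves sits ortho to the remaining fluoro group. For the measured compounds named here, no measured step touches this position, so the only guide is that the two compounds with one fluoro group on the ring both give a higher number in this assay than compound 3, with two. On that basis compound 4 is expected to move upward, by about a number 35 percentage points higher from compound 3 to compound 4 (beyond the scatter), toward the level of compound 1; the estimate for compound 4 is 85%, within a range from 50% to 100%.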

Compound 4, a percentage reported as inhibition, in the whole organism at one dose (the size of the read-out at that dose, not a potency): 100%
For compound 4 the middle estimate is 15 percentage points below the measured one; the measured number falls inside the stated range.
By their numbers in this assay, from the lowest: compound 3; then compounds 1, 2 and 4 (each within the scatter of the next).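

In this assay, for the compounds shown here, hydrogen in place of fluoro on this aromatic carbon, ortho to a fluoro group, gives a number 50 percentage points higher from compound 3 to compound 4 (beyond the scatter) and is the first measured step at this position, so this one atom separates the low read-out from the high one. The amide part does not account for that gap: cyclopropylamino in place of ethyl(methyl)amino gives no change at the digits printed from compound 2 to compound 4 (within the scatter) and cyclopropyl in place of isopropyl on the amide-type nitrogen gives no change at the digits printed from compound 1 to compound 4 (within the scatter) in the same assay. The low number of compound 3 therefore goes with its second fluoro group, not with its cyclopropylamino amide.

From the compounds shown here alone, whether a chloro or methoxy group on this carbon would lower the read-out as fluoro does remains open, and a single dose cannot separate the potency of compounds that share one number. No supporting data explain why the second fluoro group has this effect.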